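The source may hold more compounds than are shown below. What is called first, only, known or untested is meant among the compounds shown, and "the series" means these compounds.

Measured in a functional assay on PC-3 cells (Homo sapiens) for cytotoxicity, read by WST assay, with a stated time of 72 h; on this read-out higher numbers stand for weaker inhibition and lower numbers for stronger inhibition:
- compound 1 `COc1ccc(C2(c3ccc(O)cc3)C(=O)Nc3c2ccc(F)c3F)cc1`: 2 nM; 2.2 nM; > 1000 nM (3 entries)
- compound 2 `CCOc1ccc(C2(c3ccc(O)cc3)C(=O)Nc3c2ccc(F)c3F)cc1`: 24 nM

One entry for compound 1 is a limit of the assay and not a number. In this assay, among the measured compounds shown here, compound 2 stands at 24 nM, its only number, and a further entry for it carries no single number.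

Compound 3 `O=C1Nc2c(ccc(F)c2F)C1(c1ccncc1)c1ccc(O)cc1` has pyridin-4-yl in place of 4-ethoxyphenyl on a saturated ring carbon. For the measured compounds named here, this replacement has no measured precedent, since no step between measured compounds is available. Starting from compound 2 at 24 nM, the change is expected to weaken inhibition beyond the usual scatter, with an expected step of a 13-fold higher number from compound 2 to compound 3 (1.10 log units; beyond the scatter). The estimate for compound 3 is 300 nM, with an expected range from 40 nM to 3000 nM.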

Compound 3, half-maximal inhibitory concentration: 110 nM
Beside the measured number, compound 3's estimate is 2.7-fold (0.44 log units) above it, within the range that was stated.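

In this assay, the saturated ring carbon two ring bonds from the ring nitrogen now has its first readable replacement, pyridin-4-yl in place of 4-ethoxyphenyl, with a 4.6-fold higher number from compound 2 to compound 3 (0.66 log units; beyond the scatter). The step is modest, and inhibition is reduced but not lost: compound 3 gives 110 nM. Steps involving compound 1 cannot be read, since its entries disagree and one of them is a limit of the assay: the several entries of compound 1 in this assay, 2 nM; 2.2 nM; > 1000 nM (3 entries)

The step swaps the ring type and removes the ethoxy group at once, so the compounds shown do not separate the contribution of the ring nitrogen from that of the lost chain. A plain phenyl at this position would separate the two, and a pyridin-3-yl would show whether the place of the ring nitrogen matters.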